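Cyclohexyl ether of the menthol-derived scaffold

The source may report more compounds than this note shows. Statements on the series, on what has been measured and on what is new or still open speak of the compounds shown alone.

Compound 1 `C=CCc1cc(OC)c(OC(C)C(O[C@@H]2C[C@H](C)CC[C@H]2C(C)C)c2ccc(O)c(OC)c2)c(OC)c1`: 28 nM
Compound 2 `C=CCc1cc(OC)c(OC(C)C(OCC)c2ccc(O)c(OC)c2)c(OC)c1`: 332 nM
Compound 3 `C=CCc1cc(OC)c(OC(C)C(OC)c2ccc(O)c(OC)c2)c(OC)c1`: 3450 nM

In an assay on HEK293 cells for agonist activity at transient receptor potential cation channel subfamily M member 8 (Homo sapiens), read by fluorescence and calcium flux, with a stated time of 5 min (a lower number here means that less compound is needed, a higher number that more compound is needed for the effect), compound 3 gives the highest number of the three, with a 10-fold higher number from compound 2 to compound 3 (1.02 log units; beyond the scatter) and a 120-fold higher number from compound 1 to compound 3 (2.09 log units; beyond the scatter) setting it apart from the others. Compound 4 `C=CCc1cc(OC)c(OC(C)C(OC2CCCCC2)c2ccc(O)c(OC)c2)c(OC)c1` differs from compound 3 by cyclohexyl in place of methyl on an oxygen on a saturated carbon, the same position where the two measured steps sit. Both a 120-fold higher number from compound 1 to compound 3 (2.09 log units; beyond the scatter) and a 10-fold higher number from compound 2 to compound 3 (1.02 log units; beyond the scatter) were large, and the larger group on that oxygen went with the lower number. Cyclohexyl is larger than ethyl and smaller than 2-isopropyl-5-methylcyclohexyl, so a large step down is expected, estimated as a 35-fold lower number from compound 3 to compound 4 (1.54 log units; beyond the scatter). Compound 4 is therefore expected at 100 nM, ranging from 30 nM to 400 nM.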

Compound 4, half-maximal effective concentration: 54 nM
Compound 4: the middle estimate sits 1.9-fold (0.27 log units) above what was measured, within the range that was stated.
By their numbers in this assay, from the lowest: compounds 1 and 4 (each within the scatter of the next); then compound 2; then compound 3.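

In this assay cyclohexyl on the oxygen gives a 64-fold lower number from compound 3 to compound 4 (1.81 log units; beyond the scatter) and, set against ethyl, a 6.1-fold lower number from compound 2 to compound 4 (0.79 log units; beyond the scatter) so a ring without substituents already accounts for most of the drop in the number. Adding the isopropyl and methyl groups of 2-isopropyl-5-methylcyclohexyl gives a 1.9-fold higher number from compound 1 to compound 4 (0.29 log units; within the scatter) so the trend with group size seen in the earlier compounds does not clearly continue beyond cyclohexyl. As far as these compounds go, whether a phenyl ring, a cyclopentyl ring or a chain bearing an amine on this oxygen would match cyclohexyl remains open. Nothing available explains why this group has such an effect.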